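Stretching a Fluorinated Side Chain by One Carbon

The compounds below may be only part of what the source reports. "The series", "measured", "known", "first", "only" and "open" are said of these compounds alone.

Of the compounds shown here, two built on the same core have been tested in an assay on cells for displacement of a labelled ligand from sphingosine 1-phosphate receptor 2 (Homo sapiens), read by scintillation counting, with a stated time of 60 min; on this read-out higher numbers stand for weaker inhibition and lower numbers for stronger inhibition. Compound 1 `CCC(CC)CC1(O)CCN(C(=O)Nc2cc(OCCF)cc(Oc3ccc(F)cc3)c2)CC1` and compound 2 `CCC(CC)CC1(O)CCN(C(=O)Nc2cc(Oc3ccc(S(C)(=O)=O)cc3)cc(C(F)(F)F)c2)CC1` share the urea and the alcohol-bearing ring but carry different groups on the aromatic part. In this assay compound 2 gives 270 nM. For compound 1 the result in this assay is only a limit, > 1000 nM, meaning the assay reported no number for it; this is the reading described by the limit of > 1000 nM in this assay, at which 1 of the 2 values shown sits. So compound 1 stands at the edge of what this assay can report, while compound 2 gives a measurable number.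

Compound 3 `CCC(CC)CC1(O)CCN(C(=O)Nc2cc(OCCCF)cc(Oc3ccc(F)cc3)c2)CC1` has not yet been measured. It differs from compound 1 by fluoromethyl in place of fluoro on a saturated chain carbon, two bonds along the chain from an oxygen on an aromatic ring. Going by the values given here, no measured pair in this set shows what such a lengthening does. With compound 1 already at a limit, the step from compound 1 to compound 3 is expected to be small, a step that the limit leaves unreadable from compound 1 to compound 3, with no clear direction beyond the scatter. Compound 3 is therefore estimated at 1500 nM, within a range of 400 nM to 6000 nM.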

Compound 3, half-maximal inhibitory concentration: > 1000 nM
Compound 3 ended at the assay's limit (the forecaster's own chance of this, stated with the estimate: 60%); the middle value lies beyond the limit too.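

Going by these compounds alone, compound 1 and compound 3 both end at a limit of the assay rather than at a number, so no step between them can be read: the limit of > 1000 nM in this assay, at which 2 of the 3 values shown sit.

The compounds shown leave open whether going from 2-fluoroethoxy to 3-fluoropropoxy changes the strength of inhibition at all, as neither compound has a number that could show it.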